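Amide side-chain variation on a shared diaryl core

The compounds below may be only part of what the source reports. "The series", "measured", "known", "first", "only" and "open" are said of these compounds alone.

Measured so far:
compound 1, `Cn1cnnc1SCC(=O)Nc1ccc(-c2nc(-c3ccccc3)c(-c3ccccc3)n2C)cc1`: 33.1%
compound 2, `Cn1ccnc1SCC(=O)Nc1ccc(-c2nc(-c3ccccc3)c(-c3ccccc3)n2C)cc1`: 10.3%

In a functional assay on MCF7 cells (Homo sapiens) for cytotoxicity, read by MTT assay, with a stated time of 24 h, tested at 0.64 ug/mL (a higher number here means a stronger effect of the compound at the concentration tested, a lower number a weaker effect), compound 1 gives 33.1% and compound 2 gives 10.3%. Among the compounds with values here, compound 2 stands lowest of the two numbers; its nearest neighbour is compound 1, and the only measured step runs a number 22.8 percentage points lower from compound 1 to compound 2 (beyond the scatter), a heteroaryl exchange on the sulfur.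

Compound 3, `CN1CCN(CC(=O)Nc2ccc(-c3nc(-c4ccccc4)c(-c4ccccc4)n3C)cc2)CC1`, is not yet measured in this assay. It differs from compound 2 as follows: 4-methylpiperazin-1-yl in place of (1-methyl-1H-imidazol-2-yl)sulfanyl on a saturated chain carbon bound to a carbonyl carbon. Within the data shown here, no measured step covers this change: the one step known alters the group on the sulfur, whereas here the whole sulfur-linked heteroaryl leaves and a saturated amine ring enters on the chain carbon. The step from compound 1 to compound 2 shows only that this side chain can shift the read-out by a modest amount in this assay.

With nothing direct to draw on, compound 3 is expected to stay near compound 2, with a step of a number 7.7 percentage points higher from compound 2 to compound 3 (within the scatter) that may not exceed the scatter. The estimate for compound 3 in this assay is 18%, within a range of 4% to 40%.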

Compound 3, a percentage reported as activity, at one concentration (the size of the read-out at that concentration, not a potency): 1.1%
The estimate for compound 3 lay 16.9 percentage points above the measured number; measured number outside the range, below it.
By their numbers in this assay, from the lowest: compounds 3 and 2 (each within the scatter of the next); then compound 1.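

In this assay the step is a number 9.2 percentage points lower from compound 2 to compound 3 (within the scatter) when the whole (1-methyl-1H-imidazol-2-yl)sulfanyl group gives way to 4-methylpiperazin-1-yl on the saturated chain carbon bound to a carbonyl carbon, so a non-aromatic ring without sulfur cannot be told apart here from the imidazole-bearing side chain. Within the data shown here, the same entering group, set against (4-methyl-4H-1,2,4-triazol-3-yl)sulfanyl, gives a number 32 percentage points lower from compound 1 to compound 3 (beyond the scatter) and is the largest step so far; compound 1 now stands clear of both other compounds, and its side chain alone separates from the rest at this position. Nothing at hand accounts for this separation of compound 1.

Open, on these data alone, is whether the level of compound 1 follows the 4-methyl-4H-1,2,4-triazol-3-yl ring itself or needs the sulfur that carries it, a question that a triazole bound directly to the chain carbon would address. Also open, as far as these compounds go, is whether a morpholin-4-yl or a dimethylamino group on the same chain carbon would stay with compound 3 or move towards compound 1.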